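Propyl to isobutyl on an aryl selenocyanate carbamate

The compounds below may be only part of what the source reports. "The series", "measured", "known", "first", "only" and "open" are said of these compounds alone.

Measured compounds:
compound 1 `N#C[Se]c1ccc(NC(=O)Oc2ccc(F)cc2)cc1` — 37600 nM
compound 2 `CCCOC(=O)Nc1ccc([Se]C#N)cc1` — 51900 nM

Of the compounds shown here, two sharing the selenocyanate-bearing core have been measured in a functional assay on HT-29 cells (Homo sapiens) for cytotoxicity, read by MTT assay, with a stated time of 72 h; a higher number here means a weaker inhibitor of growth, a lower number a stronger inhibitor of growth. Compound 1 `N#C[Se]c1ccc(NC(=O)Oc2ccc(F)cc2)cc1` gives 37600 nM in this assay. Compound 2 `CCCOC(=O)Nc1ccc([Se]C#N)cc1` gives 51900 nM. Compound 2 stands with the higher of the two numbers, yet its gap to compound 1 lies within the scatter of repeated measurements, so the two values cannot be ordered with any confidence; both describe weak inhibitors of growth.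

Compound 3 `CC(C)COC(=O)Nc1ccc([Se]C#N)cc1` has not yet been measured. It differs from compound 2 by one change:

methyl in place of hydrogen on a saturated chain carbon bound to two saturated chain carbons

Within the data shown here, no step between measured compounds is available to calibrate this change, so the account rests on the two values alone. Both carbamates read close together, and nothing in the data points either way. The step of a 1.0-fold lower number from compound 2 to compound 3 (0.02 log units; within the scatter) is therefore expected to be small, none beyond the scatter, in either direction. Compound 3 is expected to give about 50000 nM in this assay, within a range from 20000 nM to 120000 nM.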

Compound 3, concentration for total growth inhibition: 31300 nM
For compound 3 the middle estimate is 1.6-fold (0.20 log units) above the measured one, and the stated range covers the measured number.
By their numbers in this assay, from the lowest: compounds 3, 1 and 2 (each within the scatter of the next).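

Among these compounds, this is the first step that can be read at this position: methyl in place of hydrogen on a saturated chain carbon bound to two saturated chain carbons, the change from propyl to isobutyl, gives a 1.7-fold lower number from compound 2 to compound 3 (0.22 log units; within the scatter) in this assay. The propyl chain of the carbamate therefore accepts this branch with no difference beyond the scatter, and with compound 3 at 31300 nM the reading remains that of a weak inhibitor of growth, with no sign of a gain or a loss. Nothing available bears on why the step has this size.

On these data alone, whether a longer chain such as hexyl, or a chain ending in an amine or a carboxylic acid, would move the number beyond the scatter remains open. A single step in a single assay also leaves open whether the same methyl would read alike on a shorter chain such as ethyl, and how the carbamate would fare with a thiocyanate in place of the selenocyanate.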